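This account rests on a few compounds, and the source may have more. Where it says the series, first, only, none or still open, it means among the compounds named here.

Compound 1 `CC(C)(C)c1ccc(C(=O)/C=C/c2ccc([N+](=O)[O-])o2)cc1` is an enone in which a nitrofuran is joined through a double bond to a ketone bearing a phenyl ring with a tert-butyl group. In an ADME assay on Vero cells (Chlorocebus sabaeus) for cytotoxicity, read by resazurin assay, with a stated time of 72 h (on this read-out higher numbers stand for lower toxicity in this test and lower numbers for higher toxicity in this test), compound 1 gives > 100000 nM, a limit of the assay rather than a number. Compound 3 `CC(C)(C)c1ccc(C(=O)/C=C/c2ccc([N+](=O)[O-])s2)cc1` carries a nitrothiophene in place of the nitrofuran of compound 1 and otherwise shares the same arrangement. In this assay compound 3 gives > 100000 nM, again only a limit of the assay. Compound 2 `O=C(/C=C/c1cccc([N+](=O)[O-])c1)c1ccc(N2CCCCC2)cc1` bears a nitrophenyl ring and a piperidinyl group on the phenyl ring; in this assay compound 2 gives "not determined" (no result reported), so no value can be set beside it. Compound 1 therefore stands among values that are limits only: the limit of > 100000 nM in this assay, at which 2 of the 3 values shown sit. Compound 4 `O=C(/C=C/c1ccc([N+](=O)[O-])o1)c1ccc(N2CCNCC2)cc1` differs from compound 1 by piperazin-1-yl in place of tert-butyl on an aromatic carbon. For the measured compounds named here, no measured pair shows the effect of such a change here, so the step from compound 1 to compound 4 in this assay is expected to be small, a number no higher from compound 1 to compound 4 (the limit leaves the size open), with no direction claimed beyond the scatter. For compound 4 the value in this assay is estimated at 100000 nM, between 30000 nM and 300000 nM.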

Compound 4, half-maximal cytotoxic concentration: > 100000 nM
Compound 4: no number, only a limit; the forecaster's own chance of this, stated with the estimate: 60%; the middle value lies on the limit itself.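

Compound 4 gives > 100000 nM in this assay, a limit of the assay rather than a number. For the compounds shown here, compound 1 also stands at a limit, so no step from compound 1 to compound 4 can be read. The compounds shown leave open whether piperazin-1-yl in place of tert-butyl changes this read-out at all, as most values stand at one point: the limit of > 100000 nM in this assay, at which 3 of the 4 values shown sit.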